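Swapping a propyl for a 2-fluorobenzyl on the amide

This account rests on a few compounds, and the source may have more. Where it says the series, first, only, none or still open, it means among the compounds named here.

Of the compounds shown here, three sharing one core have been tested in a functional assay on SW480 cells (Homo sapiens) for cytotoxicity, read by MTT assay, with a stated time of 24 h; on this read-out lower numbers stand for stronger inhibition and higher numbers for weaker inhibition. Compound 1 `C=CC1=C(C(=O)NCc2ccccc2)C(c2ccc(OC)cc2)OC1` gives 39500 nM. Compound 2 `C=CC1=C(C(=O)NCc2ccccc2F)C(c2ccc(F)cc2)OC1` reaches only the limit of the assay, > 100000 nM. Compound 3 `C=CC1=C(C(=O)NCCC)C(c2ccc(OC)cc2)OC1` likewise returns only a limit, > 100000 nM. Compound 3 therefore stands at the weak end of what has been seen so far, with no actual number to its name, and the same is true of one further compound; two of the three results sit at the limit of > 100000 nM in this assay, at which 2 of the 3 values shown sit.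

Compound 4 `C=CC1=C(C(=O)NCc2ccccc2F)C(c2ccc(OC)cc2)OC1` has not yet been measured. It differs from compound 3 in one place: 2-fluorophenyl in place of ethyl on a saturated chain carbon bound to an amide-type nitrogen. The closest measured step runs the other way, where an ethyl replaced a phenyl on that same carbon and the number rose an at least 2.5-fold higher number from compound 1 to compound 3 (0.40 log units; beyond the scatter). Putting an aromatic ring back on that carbon should therefore pull the number down again, although compound 2, which carries the same 2-fluorobenzyl, only reached a limit. Compound 4 is thus expected to land near 50000 nM, within a range of 25000 nM to 110000 nM, which would mean an estimated step of an at least 2.0-fold lower number from compound 3 to compound 4 (0.30 log units; that floor lies within the scatter) in this assay.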

Compound 4, half-maximal inhibitory concentration: > 100000 nM
Compound 4 was reported as a limit; the forecaster's own chance of this, stated with the estimate: 40%; middle value at least 2.0-fold (0.30 log units) away from the limit.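

In this assay, putting fluoro in place of hydrogen on an aromatic carbon of the benzyl group gives an at least 2.5-fold higher number from compound 1 to compound 4 (0.40 log units; beyond the scatter), so an aromatic ring on the saturated chain carbon bound to the amide nitrogen does not by itself keep a measurable result. Among the three compounds that share the methoxy group, only compound 1, with its plain benzyl, gives an actual number, 39500 nM. The steps to compound 4 from compound 3 and from compound 2 cannot be read, because compound 2, compound 3 and compound 4 all stand at a limit: the limit of > 100000 nM in this assay, at which 3 of the 4 values shown sit.

The compounds shown leave open whether this change belongs to fluoro in particular or would also follow from a chloro or a methyl group on the same benzyl ring. They also leave open how an amide carrying a longer chain, or an amine such as a piperidine, would compare with the plain benzyl of compound 1, and how far apart the compounds at the limit truly lie.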